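Swapping Isopropoxy for Fluoro on a Triazole Scaffold

The compounds below may be only part of what the source reports. "The series", "measured", "known", "first", "only" and "open" are said of these compounds alone.

Measured compounds:
compound 1 `COc1cc(-n2ncnc2-c2cccc([N+](=O)[O-])c2)cc(OC)c1OC`: > 10000 nM
compound 2 `COc1cc(-n2ncnc2-c2ccc(OC(C)C)cc2)cc(OC)c1OC`: 600 nM
compound 3 `COc1cc(-c2ncnn2-c2ccccc2)cc(OC)c1OC`: > 10000 nM

Among the compounds with values here, in a functional assay on HeLa cells (Homo sapiens) for antiproliferative activity, read by MTT assay, with a stated time of 72 h (on this read-out lower numbers stand for stronger inhibition and higher numbers for weaker inhibition), compound 2 gives 600 nM, the only actual number among the three. Compound 1 reaches only the assay limit, > 10000 nM. Compound 3 likewise reaches only the limit, > 10000 nM. Both of them sit at the limit of > 10000 nM in this assay, at which 2 of the 3 values shown sit. Compound 4 `COc1cc(-n2ncnc2-c2ccc(F)cc2)cc(OC)c1OC` is still to be tested. It differs from compound 2 by fluoro in place of isopropoxy on an aromatic carbon. Within the data shown here, no step between measured compounds is available to guide this change, so the expectation rests on compound 2 alone. A weakening step beyond the scatter, a 5.0-fold higher number from compound 2 to compound 4 (0.70 log units; beyond the scatter), is expected, with a real chance that only the limit is reported. The estimate for compound 4 is 3000 nM, within 800 nM to 12000 nM.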

Compound 4, half-maximal inhibitory concentration: > 10000 nM
Compound 4 ended at the assay's limit; the forecaster's own chance of this, stated with the estimate: 35%; middle value at least 3.3-fold (0.52 log units) from the limit.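

Putting fluoro in place of isopropoxy gives an at least 16-fold higher number from compound 2 to compound 4 (1.22 log units; beyond the scatter) in this assay, so activity at this aromatic carbon depends strongly on which group sits there, a dependence that compound 2 alone could not show. Compound 4 stands at a limit of the assay, not at a true number, so the full size of the step stays unknown: the limit of > 10000 nM in this assay, at which 3 of the 4 values shown sit.

On these data alone, whether the oxygen or the carbons of isopropoxy count remains open. A methoxy group, a longer chain such as butoxy, or an amine at this place would help separate the two.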